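Tert-butyl on a benzyl arm: a repeated change, new core

The source may report more compounds than this note shows. Statements on the series, on what has been measured and on what is new or still open speak of the compounds shown alone.

Measured so far:
compound 1, `CC(=O)OC[C@H]1O[C@@H](n2cc(-c3cc(-c4ccc(C(C)(C)C)cc4)no3)c(=O)[nH]c2=O)C[C@@H]1OC(C)=O`: 32.8%
compound 2, `CC(=O)OC[C@H]1O[C@@H](n2cc(-c3cc(-c4ccccc4)no3)c(=O)[nH]c2=O)C[C@@H]1OC(C)=O`: 87.6%
compound 3, `CC(=O)OC[C@H]1O[C@@H](n2cc(-c3cn(Cc4ccccc4)nn3)c(=O)[nH]c2=O)C[C@@H]1OC(C)=O`: 88.7%

The three compounds were tested in a functional assay on NUGC-3 cells (Homo sapiens) for cytotoxicity, read by sulforhodamine B assay, tested at 10 uM; a higher number here means more inhibition at the concentration tested (going by the name of the read-out), a lower number less inhibition. Compound 2 gives 87.6%, and its partner compound 1 differs from it in one place, (tert-butyl in place of hydrogen on an aromatic carbon). That single change produced a number 54.8 percentage points lower from compound 2 to compound 1 (beyond the scatter), a drop far beyond the usual scatter of the read-out.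

Compound 3 carries a different core; how its core differs from that of compound 2 is not broken down here. In this assay compound 3 gives 88.7%, and the values of compound 3 and compound 2 lie within the scatter of each other, so nothing can be said about an order between them.

Compound 4, `CC(=O)OC[C@H]1O[C@@H](n2cc(-c3cn(Cc4ccc(C(C)(C)C)cc4)nn3)c(=O)[nH]c2=O)C[C@@H]1OC(C)=O`, has not yet been measured. It differs from compound 3 by tert-butyl in place of hydrogen on an aromatic carbon, the same change that separates compound 1 from compound 2, with the same surroundings at the place of the change. Because the earlier step of a number 54.8 percentage points lower from compound 2 to compound 1 (beyond the scatter) was large and downward, a step of similar direction is expected here, estimated as a number 48.7 percentage points lower from compound 3 to compound 4 (beyond the scatter). That this is a new core, and the change is seen only once before, keeps the expectation wide. Compound 4 is expected to give about 40% in this assay, most likely between 15% and 75%.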

Compound 4, a percentage reported as inhibition, at one concentration (the size of the read-out at that concentration, not a potency): 94.2%
Compound 4: middle estimate off by 54.2 percentage points, on the low side; measured number outside the range, above it.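

In this assay, tert-butyl in place of hydrogen on the aromatic carbon of the benzyl arm gave a number 5.5 percentage points higher from compound 3 to compound 4 (within the scatter), so the large drop seen with the same change on the other core did not recur here. In this series the effect of the change therefore did not carry from one core to the other, and the step from one core gave no usable guide to the step on the other: the same change on two cores in this assay, a number 54.8 percentage points lower (beyond the scatter) from compound 2 to compound 1 and a number 5.5 percentage points higher (within the scatter) from compound 3 to compound 4, 60.3 percentage points apart, beyond the scatter of two such steps. This rests on just two matched pairs and does not show which difference between the two cores lies behind the gap, and each number is the size of the read-out at a single concentration, so this measurement does not show whether compound 3 and compound 4 would differ in the strength of their effect at other concentrations.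

The compounds shown leave open whether a smaller group such as methyl, or an amine or a carboxylic acid, on the same aromatic carbon would follow compound 1 or compound 4 on either core. They also leave open whether the gap between the two steps would persist with free hydroxyl groups in place of the acetate esters on the sugar.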